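From compound 2 to compound 3: adding a nitro group

The compounds below may be only part of what the source reports. "The series", "measured", "known", "first", "only" and "open" are said of these compounds alone.

Measured in a functional assay on Jurkat cells (Homo sapiens) for antiproliferative activity, read by MTT assay, with a stated time of 72 h; a lower number here means a stronger inhibitor, a higher number a weaker inhibitor:
Compound 1 `COc1cc(-c2ncnn2-c2cccc(N)c2)cc(OC)c1OC`: > 10000 nM
Compound 2 `COc1cc(-c2ncnn2-c2ccccc2)cc(OC)c1OC`: > 10000 nM

In this assay compound 2 stands at > 10000 nM and this is a limit of the assay rather than a number. Compound 3 `COc1cc(-c2ncnn2-c2cccc([N+](=O)[O-])c2)cc(OC)c1OC` differs from it by nitro in place of hydrogen on an aromatic carbon with nitro in place of hydrogen on an aromatic carbon. Going by the values given here, the one measured step that the two limits leave unreadable from compound 1 to compound 2 has no readable size and gives no guide. Because of the limit of > 10000 nM in this assay, at which 2 of the 2 values shown sit, no step beyond the scatter is expected in this assay in either direction. The expected step is a number no higher from compound 2 to compound 3 (the limit leaves the size open) for now. Compound 3 is estimated at 10000 nM (expected range 3000 nM to 30000 nM).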

Compound 3, half-maximal inhibitory concentration: > 10000 nM
Compound 3 was reported as a limit; the forecaster's own chance of this, stated with the estimate: 85%; the middle value sits exactly at the limit.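

No step can be read among compound 1, compound 2 and compound 3 in this assay because each is reported only as a limit: the limit of > 10000 nM in this assay, at which 3 of the 3 values shown sit. These compounds leave open how strongly each one acts, and whether amino, hydrogen or nitro on the shared core makes any difference.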